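Recovering potency by changing the substituent on the carbonyl

The source may report more compounds than this note shows. Statements on the series, on what has been measured and on what is new or still open speak of the compounds shown alone.

Of the compounds shown here, three share a common core and have been measured in a functional assay on HUVEC cells (Homo sapiens) for inhibition; a lower number here means a stronger inhibitor, a higher number a weaker inhibitor. Compound 1 `CN(c1ccc(NC(=O)Nc2ccccc2)cc1)c1ccnc(Nc2cccc(CS(C)(=O)=O)c2)n1` gives 0.2 nM. Compound 2 `CN(c1ccc(NC(=O)Oc2ccccc2)cc1)c1ccnc(Nc2cccc(CS(C)(=O)=O)c2)n1` gives 224 nM, and compound 3 `CN(c1ccc(NC(=N)Nc2ccccc2)cc1)c1ccnc(Nc2cccc(CS(C)(=O)=O)c2)n1` gives 596 nM. Compound 2 thus stands second highest of the three numbers: its nearest neighbour is compound 3, with a 2.7-fold higher number from compound 2 to compound 3 (0.42 log units; beyond the scatter), and its furthest is compound 1, with a 1100-fold higher number from compound 1 to compound 2 (3.05 log units; beyond the scatter).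

The step now followed leads from compound 2 to compound 4 `CN(C)CCNC(=O)Nc1ccc(N(C)c2ccnc(Nc3cccc(CS(C)(=O)=O)c3)n2)cc1`, with the change ((2-(dimethylamino)ethyl)amino in place of phenoxy on a carbonyl carbon). The measured step that bears most on it is the reverse of what happened between compound 1 and compound 2, where phenoxy in place of anilino on the carbonyl carbon gave a 1100-fold higher number from compound 1 to compound 2 (3.05 log units; beyond the scatter), a large rise. Putting a nitrogen-linked group back on that carbonyl carbon, here (2-(dimethylamino)ethyl)amino rather than anilino, is therefore expected to bring the number down again, though the entering group lacks the ring of anilino, so the full return is uncertain. Compound 4 is expected to give 4 nM, within 0.4 nM to 40 nM, an expected step of a 56-fold lower number from compound 2 to compound 4 (1.75 log units; beyond the scatter).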

Compound 4, half-maximal inhibitory concentration: 530 nM
Beside the measured number, compound 4's estimate is 130-fold (2.12 log units) below it; measured number outside the range, above it.
By their numbers in this assay, from the lowest: compound 1; then compound 2; then compounds 4 and 3 (each within the scatter of the next).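

Putting a nitrogen back on the carbonyl carbon did not by itself restore activity: in this assay, (2-(dimethylamino)ethyl)amino in place of phenoxy gave a 2.4-fold higher number from compound 2 to compound 4 (0.37 log units; beyond the scatter). What sits on that amide-type nitrogen therefore matters as much as the nitrogen itself, since 2-(dimethylamino)ethyl in place of phenyl gave a 2700-fold higher number from compound 1 to compound 4 (3.42 log units; beyond the scatter), a large loss. Compound 4 also cannot be told apart from the other weak compound, with a 1.1-fold lower number from compound 3 to compound 4 (0.05 log units; within the scatter), so among these compounds only the anilino group of compound 1 gives a sub-nanomolar number.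

Nothing given here explains why the phenyl group on that nitrogen matters so much. Going by these compounds, it remains open whether an aromatic ring is required there, or whether a cyclohexyl or benzyl group on that nitrogen would hold the activity of compound 1.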